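Shifting the Pyridine Nitrogen: From Compound 3 to Compound 4

The source may report more compounds than this note shows. Statements on the series, on what has been measured and on what is new or still open speak of the compounds shown alone.

Compound 3 `O=C(CCC1CCCCC1)Nc1ncc(Cc2ccccn2)s1` belongs to a small set of three compounds that share one core and differ only in the aromatic group carried on a saturated chain carbon bound to an aromatic carbon. In an ADME assay on P388D1 cells (Mus musculus) for cytotoxicity, read by fluorescence and resazurin assay, with a stated time of 72 h (on this read-out higher numbers stand for weaker inhibition and lower numbers for stronger inhibition), compound 3 gives > 40000 nM, and this is a limit of the assay, not a measured number. Compound 1 `O=C(CCC1CCCCC1)Nc1ncc(Cc2ccccc2)s1` carries a phenyl in the same place. In this assay compound 1 gives > 40000 nM, again a limit rather than a number. For compound 2 `O=C(Nc1ncc(Cc2cc3sccc3s2)s1)C1CCCCC1` the entry in this assay reads "not determined" (no result reported). The step that the two limits leave unreadable from compound 1 to compound 3 cannot be sized because both of its values sit at the limit of > 40000 nM in this assay, at which 2 of the 3 values shown sit.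

Compound 4 `O=C(CCC1CCCCC1)Nc1ncc(Cc2ccncc2)s1` differs from compound 3 in one place: pyridin-4-yl in place of pyridin-2-yl on a saturated chain carbon bound to an aromatic carbon. No measured step bears on this change, since the only step shown is unreadable, and the set gives no direction beyond the scatter to expect. The step from compound 3 to compound 4 is therefore expected to be a step that the limit leaves unreadable from compound 3 to compound 4, which is to say no readable change. Compound 4 is expected to give about 60000 nM in this assay, within a range from 20000 nM to 200000 nM, most likely reported only as a limit.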

Compound 4, half-maximal inhibitory concentration in the P388D1 assay: > 40000 nM
Compound 4 gave a limit, no number (the forecaster's own chance of this, stated with the estimate: 80%); the middle value is on the limit's open side.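

In the P388D1 assay compound 4 gives > 40000 nM as a limit of the assay and not a number. Compound 1 and compound 3 sit at the same limit, so the steps from compound 1 and from compound 3 to compound 4 cannot be read. The compounds shown leave open whether pyridin-4-yl, pyridin-2-yl or phenyl in this place makes any difference to the cytotoxicity read-out. In a physicochemical assay for solubility, at pH 5 (on this read-out higher numbers stand for higher solubility and lower numbers for lower solubility), compound 3 gives 60 ug/mL and compound 4 gives 140 ug/mL and this is a 2.3-fold higher number from compound 3 to compound 4 (0.37 log units; beyond the scatter) with pyridin-4-yl in place of pyridin-2-yl on a saturated chain carbon bound to an aromatic carbon.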